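The source may hold more compounds than are shown below. What is called first, only, known or untested is meant among the compounds shown, and "the series" means these compounds.

Compound 1 `O=c1cc(CSc2nc3ccccc3s2)oc2ccccc12` gives in a functional assay on MDA-MB-435S cells (Homo sapiens) for cytotoxicity, read by MTT assay, with a stated time of 72 h (on this read-out lower numbers stand for stronger inhibition and higher numbers for weaker inhibition), only the limit > 25000 nM.
Compound 2 `Cc1cc(C)n2nc(SCc3nnc(SCc4coc5ccccc5c4=O)n3N)nc2n1` gives in this assay 3000 nM.
Compound 3 `Cc1cc(C)n2nc(SCc3nnc(SCc4coc5ccccc5c4=O)n3-c3ccccc3)nc2n1` gives in this assay 2900 nM.

On these numbers compound 3 sits at the lowest value; compound 2 is nearest, and the step of a 1.0-fold lower number from compound 2 to compound 3 (0.01 log units; within the scatter) lies within the scatter, so the two cannot be ordered. Compound 4 `Cc1cc(C)n2nc(SCc3nnc(SCc4cc(=O)c5ccccc5o4)n3-c3ccccc3)nc2n1` differs from compound 3 by a group of 11 heavy atoms (9 carbon, 2 oxygen; one six-membered aromatic ring of carbon only, one six-membered aromatic ring with 1 hetero atom) in place of a group of 11 heavy atoms (9 carbon, 2 oxygen; one six-membered aromatic ring of carbon only, one six-membered aromatic ring with 1 hetero atom), on a saturated chain carbon bound to a sulfur. Among the compounds with values here, no measured step tests such a rearrangement: the only measured step, from compound 2 to compound 3, changes a group on an aromatic nitrogen and is within the scatter. Compound 1 differs from compound 4 in more than one place and gives only a limit. Compound 4 is therefore expected near compound 3, with the estimated step of a 1.4-fold higher number from compound 3 to compound 4 (0.14 log units; within the scatter) and an estimated value of 4000 nM (range 1500 nM to 15000 nM).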

Compound 4, half-maximal inhibitory concentration: > 25000 nM
Compound 4: only a limit was reported; the forecaster's own chance of this, stated with the estimate: 15%; middle value at least 6.2-fold (0.79 log units) away from the limit.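

Which of the two groups sits on a saturated chain carbon bound to a sulfur matters in this series: with the same atoms joined differently, the change gives an at least 8.6-fold higher number from compound 3 to compound 4 (0.93 log units; beyond the scatter). The earlier step changed only a group on an aromatic nitrogen and stayed within the scatter, so this is the first change shown to move the read-out. Compound 4 gives only a limit in this assay: the limit of > 25000 nM in this assay, at which 2 of the 4 values shown sit.

From the compounds shown here alone, how far the true value of compound 4 lies past that limit remains open. So does what a carboxylic acid or an amine would give at this place on the chain.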